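Changing the Aryl Group on the Saturated Ring Carbon

The compounds below may be only part of what the source reports. "The series", "measured", "known", "first", "only" and "open" are said of these compounds alone.

Measured so far:
compound 1, `N#CC1=C(N)N(c2ccc(S(N)(=O)=O)cc2)C2=C(CCCC2)C1c1ccccc1O`, 50%
compound 2, `N#CC1=C(N)N(c2ccc(S(N)(=O)=O)cc2)C2=C(CCCC2)C1c1cccc([N+](=O)[O-])c1`, 2%

In a functional assay on Ehrlich cells (Mus musculus) for cytotoxicity, read by trypan blue exclusion, with a stated time of 2 h, tested at 50 ug/mL (a higher number here means a stronger effect of the compound at the concentration tested, a lower number a weaker effect), compound 2 stands lowest of the two numbers measured; its nearest neighbour is compound 1, separated by the step of a number 48 percentage points lower from compound 1 to compound 2 (beyond the scatter). Compound 3, `N#CC1=C(N)N(c2ccc(S(N)(=O)=O)cc2)C2=C(CCCC2)C1c1ccccc1Cl`, differs from compound 2 only in this respect: 2-chlorophenyl in place of 3-nitrophenyl on a saturated ring carbon. Going by the values given here, the one measured step that bears on this change is a number 48 percentage points lower from compound 1 to compound 2 (beyond the scatter), a large fall when 3-nitrophenyl replaced 2-hydroxyphenyl. Among the compounds with values here, compound 3 reverses that exchange only in part, since 2-chlorophenyl is not 2-hydroxyphenyl and no chlorine-bearing analogue has been measured. The step in this assay is therefore estimated as a number 33 percentage points higher from compound 2 to compound 3 (beyond the scatter), an expected rise that carries wide uncertainty. Compound 3 is estimated at 35% in this assay, within a range from 5% to 65%.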

Compound 3, a percentage reported as activity, at one concentration (the size of the read-out at that concentration, not a potency): 5%
For compound 3 the middle estimate is 30 percentage points above the measured one; measured number inside the range.
By their numbers in this assay, from the lowest: compounds 2 and 3 (each within the scatter of the next); then compound 1.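

In this assay, putting 2-chlorophenyl in place of 3-nitrophenyl on the saturated ring carbon gives a number 3 percentage points higher from compound 2 to compound 3 (within the scatter), so these two aryl groups cannot be told apart in this read-out. Going by these compounds alone, the closer comparison, chloro in place of hydroxy on an aromatic carbon, gives a number 45 percentage points lower from compound 1 to compound 3 (beyond the scatter), which shows that this single exchange on the phenyl ring is enough for a large step and that, of the three compounds, only the one with 2-hydroxyphenyl stands apart. Nothing available here accounts for that difference.

From the compounds shown here alone, whether the hydroxy group is itself what matters stays open, and a methoxy group, an amine or a carboxylic acid on the same ring would test this. So too does whether 3-hydroxyphenyl or 4-hydroxyphenyl would match 2-hydroxyphenyl.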